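Iodo to ethynyl on a nucleoside at the assay limit

This account rests on a few compounds, and the source may have more. Where it says the series, first, only, none or still open, it means among the compounds named here.

Compound 3 `COc1ncnc2c1c(I)cn2[C@@H]1O[C@H](CO)[C@@H](O)[C@H]1O` sits at the edge of what this assay reports: in a functional assay on HCT-116 cells (Homo sapiens), read by MTT assay, with a stated time of 72 h (a lower number here means a stronger inhibitor, a higher number a weaker inhibitor), compound 3 gives > 20000 nM, which is a limit and not a number. Compound 4 `C#Cc1cn([C@@H]2O[C@H](CO)[C@@H](O)[C@H]2O)c2ncnc(OC)c12` differs from compound 3 in one place: ethynyl in place of iodo on an aromatic carbon. Among the compounds with values here, the only measured step, an at least 1.4-fold lower number from compound 1 to compound 2 (0.15 log units; that floor lies within the scatter), changes a different group on a different core, so it does not bear on this change. In this assay compound 1 `Nc1nc(N)c2c(-c3ccsc3)cn([C@@H]3O[C@H](CO)[C@@H](O)[C@H]3O)c2n1` gives > 20000 nM, a limit. In this assay compound 2 `Nc1nc(N)c2c(-c3cc4ccccc4o3)cn([C@@H]3O[C@H](CO)[C@@H](O)[C@H]3O)c2n1` gives 14000 nM. Two of the three known values sit at the limit of > 20000 nM in this assay, at which 2 of the 3 values shown sit. Within the data shown here, with no step that bears on it, the expected step is a number no higher from compound 3 to compound 4 (the limit leaves the size open), within the scatter. Compound 4 is estimated at 20000 nM, with a range from 8000 nM to 50000 nM.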

Compound 4, half-maximal inhibitory concentration: 5140 nM
Compound 4: middle estimate off by 3.9-fold (0.59 log units), on the high side; the whole stated range lies above it.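

In this assay, ethynyl in place of iodo gives an at least 3.8-fold lower number from compound 3 to compound 4 (0.59 log units; beyond the scatter). The group on this aromatic carbon therefore affects the read-out on this core, even though the change adds no ring and no hydrogen-bond donors or acceptors. The step gives only a floor, and its full size stays open, because compound 3 stands at a limit: the limit of > 20000 nM in this assay, at which 2 of the 4 values shown sit.

The compounds shown leave open whether an amine or a longer chain on this carbon would lower the number further. They also leave open whether ethynyl would act alike on the core of compound 1.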